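The source may hold more compounds than are shown below. What is called first, only, known or untested is meant among the compounds shown, and "the series" means these compounds.

Measured so far: compound 1 `C=C(C)CN(CC)Cc1c(C(F)(F)F)nc2n(-c3c(C)cc(C)cc3C)c(Cl)cn12` gives 67 nM in an assay on cells for displacement of a labelled ligand from corticotropin-releasing factor receptor 1 (Homo sapiens), with a stated time of 100 min; a higher number here means a weaker inhibitor, a lower number a stronger inhibitor; compound 2 `CCN(Cc1c(C(F)(F)F)nc2n(-c3c(C)cc(C)cc3C)c(Cl)cn12)CC1CCC1` gives 16 nM.

Among the measured compounds shown here, compound 2 holds the lowest number of the two measured; its only neighbour is separated by a 4.2-fold lower number from compound 1 to compound 2 (0.62 log units; beyond the scatter). Compound 3 `Cc1cc(C)c(-n2c(Cl)cn3c(CN(C)Cc4ccccc4)c(C(F)(F)F)nc23)c(C)c1` differs from compound 2 by benzyl(methyl)amino in place of (cyclobutylmethyl)(ethyl)amino on a saturated chain carbon bound to an aromatic carbon. For the measured compounds named here, no measured step bears on this change directly: the single step known alters only the ring on the amine side chain and was modest in size. Going by the values given here, with no precedent for the benzyl(methyl)amino group, a step of roughly a 2.5-fold higher number from compound 2 to compound 3 (0.40 log units; beyond the scatter) is expected, leaning toward a slightly higher number. Compound 3 is estimated at 40 nM, with a range of 10 nM to 160 nM.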

Compound 3, inhibition constant: 160 nM
Beside the measured number, compound 3's estimate is 4.0-fold (0.60 log units) below it, and the stated range covers the measured number.
By their numbers in this assay, from the lowest: compound 2; then compound 1; then compound 3.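

In this assay, benzyl(methyl)amino is a poorer fit on this saturated chain carbon bound to an aromatic carbon than (cyclobutylmethyl)(ethyl)amino (a 10-fold higher number from compound 2 to compound 3 (1.00 log units; beyond the scatter)) or ethyl(2-methylprop-2-en-1-yl)amino (a 2.4-fold higher number from compound 1 to compound 3 (0.38 log units; beyond the scatter)). Both steps lie beyond the scatter, so among these three amines the one carrying a six-membered aromatic ring has the highest number. No supporting data explain this difference.

Compound 3 changes the ring and replaces ethyl with methyl on the amine together, so their separate contributions remain unresolved. A benzyl(ethyl)amino or cyclohexylmethyl(ethyl)amino group would help separate them.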